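Notes on the carbonyl substituent in this series

The source may hold more compounds than are shown below. What is called first, only, known or untested is meant among the compounds shown, and "the series" means these compounds.

Compound 1 `COc1cc(-c2nn(-c3cccc(NC(=O)Nc4ccc(Cl)c(Cl)c4)c3)cc2-c2ccncc2)ccc1Cl` and compound 2 `COc1cc(-c2nn(-c3cccc(NC(=O)Nc4ccc(Cl)c(C(F)(F)F)c4)c3)cc2-c2ccncc2)ccc1Cl` share one core and differ only in the group on an aromatic carbon. In a functional assay on SK-MEL-2 cells (Homo sapiens) for inhibition, read by sulforhodamine B assay, with a stated time of 48 h (a higher number here means that more compound is tolerated, a lower number that less compound is tolerated), compound 1 gives 4850 nM, and compound 2 gives 17500 nM. The measured step, a 3.6-fold higher number from compound 1 to compound 2 (0.56 log units; beyond the scatter), is the only one available. Compound 2 therefore stands at the highest of the two numbers, with compound 1 nearest to it.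

Compound 3 `COc1cc(-c2nn(-c3cccc(NC(=O)c4ccccc4)c3)cc2-c2ccncc2)ccc1Cl` is unmeasured; relative to compound 2 the change is phenyl in place of (4-chloro-3-(trifluoromethyl)phenyl)amino on a carbonyl carbon. Within the data shown here, this removes the whole substituted aryl amino group rather than exchanging one substituent on it, so the one measured step bears only loosely on it: it shows that a modest alteration on that aryl group already moved the number beyond the scatter, towards more compound tolerated. Among the measured compounds shown here, on that basis the step from compound 2 to compound 3 is expected to be a 1.4-fold higher number from compound 2 to compound 3 (0.15 log units; within the scatter), in the same direction, though no measured pair secures the direction. Compound 3 is accordingly estimated at 25000 nM in this assay, with a range of 6000 nM to 100000 nM.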

Compound 3, concentration lethal to 50% of the cells: > 100000 nM
Compound 3 was reported as a limit (the forecaster's own chance of this, stated with the estimate: 25%); middle value at least 4.0-fold (0.60 log units) from the limit.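

In this assay, phenyl in place of (4-chloro-3-(trifluoromethyl)phenyl)amino on a carbonyl carbon gives an at least 5.7-fold higher number from compound 2 to compound 3 (0.75 log units; beyond the scatter), and phenyl in place of (3,4-dichlorophenyl)amino gives an at least 20-fold higher number from compound 1 to compound 3 (1.31 log units; beyond the scatter). The value of compound 3 is a limit and not a number: the limit of > 100000 nM in this assay, at which 1 of the 3 values shown sits. Among these three compounds, the lower numbers go with a substituted phenylamino group on the carbonyl carbon, so this position carries more than the exchange of chloro for trifluoromethyl alone could show, a 3.6-fold higher number from compound 1 to compound 2 (0.56 log units; beyond the scatter).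

Compound 3 loses the amino nitrogen and the ring substituents together, so the compounds shown do not separate the two changes. Going by these compounds, whether an unsubstituted phenylamino group, a benzylamino group or a simple alkylamino chain on the carbonyl carbon would keep the lower numbers remains open.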